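This account rests on a few compounds, and the source may have more. Where it says the series, first, only, none or still open, it means among the compounds named here.

Compound 1 `Cc1cc(C)cc(C(=O)c2cc(Cl)ccc2Oc2ccnc(Nc3ccc(C#N)cc3)n2)c1` gives 28800 nM in an ADME assay on MT4 cells (Homo sapiens) for cytotoxicity, read by MTT assay, with a stated time of 5 days; on this read-out lower numbers stand for higher toxicity in this test and higher numbers for lower toxicity in this test. Compound 2 `Cc1ccccc1C(=O)c1cc(Cl)ccc1Oc1ccnc(Nc2ccc(C#N)cc2)n1` gives 28800 nM in this assay; the two differ by 2-methylphenyl in place of 3,5-dimethylphenyl on a carbonyl carbon, which makes no change at the digits printed from compound 1 to compound 2 (within the scatter). Compound 3 `Cc1cc(C)cc(C(=O)c2cc(Cl)ccc2Oc2nc(Nc3ccc(C#N)cc3)ncc2C)c1` carries a different core, the difference being (methyl in place of hydrogen on an aromatic carbon). In this assay, within the data shown here, compound 3 gives 13400 nM, which is a 2.1-fold lower number from compound 1 to compound 3 (0.33 log units; beyond the scatter) and the lowest of the three numbers so far. Compound 4 `Cc1ccccc1C(=O)c1cc(Cl)ccc1Oc1nc(Nc2ccc(C#N)cc2)ncc1C` has not yet been measured. It differs from compound 3 by 2-methylphenyl in place of 3,5-dimethylphenyl on a carbonyl carbon, the same change that separates compound 1 from compound 2, at a place described in the same words; in the compounds shown this change occurs twice in all. Among the measured compounds shown here, the step expected from compound 3 to compound 4 in this assay is no change at the digits printed from compound 3 to compound 4 (within the scatter), set beside the earlier no change at the digits printed from compound 1 to compound 2 (within the scatter), and it rests on that single measured pair alone, because no change at the digits printed from compound 1 to compound 2 (within the scatter) is the only guide to this change. Compound 4 is estimated at 13400 nM, with a range from 6700 nM to 27000 nM.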

Compound 4, half-maximal cytotoxic concentration: 24200 nM
For compound 4 the middle estimate is 1.8-fold (0.26 log units) below the measured one, and the stated range covers the measured number.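

The change to 2-methylphenyl in place of 3,5-dimethylphenyl on a carbonyl carbon gives a 1.8-fold higher number from compound 3 to compound 4 (0.26 log units; within the scatter) in this assay, and the two cores do not separate on this change: the same change on two cores in this assay, no change at the digits printed (within the scatter) from compound 1 to compound 2 and a 1.8-fold higher number (0.26 log units; within the scatter) from compound 3 to compound 4, 1.8-fold (0.26 log units) apart, within the scatter of two such steps. The second change, methyl in place of hydrogen on an aromatic carbon, gives a 1.2-fold lower number from compound 2 to compound 4 (0.08 log units; within the scatter), and again the gap between the two cores stays inside what repeated measurements would produce: the same change on two cores in this assay, a 2.1-fold lower number (0.33 log units; beyond the scatter) from compound 1 to compound 3 and a 1.2-fold lower number (0.08 log units; within the scatter) from compound 2 to compound 4, 1.8-fold (0.26 log units) apart, within the scatter of two such steps. Within these four compounds, each change can therefore be carried from one core to the other without a detectable difference, but this rests on two pairs per change in a single assay and does not show that the steps are identical or that they would hold on any further core.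

The compounds shown leave open whether the pattern extends to groups of another kind on the carbonyl carbon, such as an amine or a carboxylic acid in place of the methyl-bearing phenyl groups. They also leave open whether a longer chain in place of the added methyl would behave in the same way.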